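The source may hold more compounds than are shown below. What is called first, only, known or untested is meant among the compounds shown, and "the series" means these compounds.

Measured so far:
- compound 1 `O=C(OC1CCC(CN2CCN(c3cc(=O)c4cc(C(F)(F)F)cc([N+](=O)[O-])c4s3)CC2)CC1)c1ccccc1`: 0.903 h
- compound 2 `CS(=O)(=O)NC1CCC(CN2CCN(c3cc(=O)c4cc(C(F)(F)F)cc([N+](=O)[O-])c4s3)CC2)CC1`: > 1.55 h (a limit)

Within the data shown here, in an ADME assay on cells (Hepatocyte, Mus musculus) for metabolic stability (on this read-out higher numbers stand for a longer-lived compound and lower numbers for a shorter-lived compound), compound 1 gives 0.903 h, the only true number so far. The value of compound 2 is a limit of the assay. Compound 3 `O=C(OC1CCC(CN2CCN(c3cc(=O)c4cc(C(F)(F)F)cc([N+](=O)[O-])c4s3)CC2)CC1)c1ccncc1` keeps the ester of compound 1 and carries pyridin-4-yl in place of phenyl on a carbonyl carbon, pyridin-4-yl in place of phenyl on a carbonyl carbon. Among the measured compounds shown here, the one measured step, an at least 1.7-fold higher number from compound 1 to compound 2 (0.23 log units; that floor lies within the scatter), has a floor within the scatter and replaces the whole benzoyloxy group, so it offers only a weak guide. No step beyond the scatter is expected, and the estimated step is a 1.1-fold lower number from compound 1 to compound 3 (0.05 log units; within the scatter). For compound 3 the estimate is 0.8 h, with an expected range of 0.4 h to 1.6 h.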

Compound 3, half-life: 0.0817 h
For compound 3 the middle estimate is 9.8-fold (0.99 log units) above the measured one; the whole stated range lies above it.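

In this assay, pyridin-4-yl in place of phenyl on a carbonyl carbon gives an 11-fold lower number from compound 1 to compound 3 (1.04 log units; beyond the scatter): with the ester kept, exchanging one ring carbon for nitrogen is enough to move this read-out beyond the scatter. Swapping the whole group for methanesulfonamido reads as an at least 18-fold lower number from compound 2 to compound 3 (1.27 log units; beyond the scatter). The value of compound 2 is a limit, so that step is only a floor: the limit of > 1.55 h in this assay, at which 1 of the 3 values shown sits.

Open, going by these compounds, is whether the drop depends on where the ring nitrogen sits, as pyridin-3-yl would show. Also open, on these data alone, is whether it persists with an amide in place of the ester.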